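Fluoro in place of ethoxy on the aryl of compound 2

This account rests on a few compounds, and the source may have more. Where it says the series, first, only, none or still open, it means among the compounds named here.

Three compounds of the series have numbers in a functional assay on L1210 cells (Mus musculus) for inhibition, read by cell counting, with a stated time of 2 days; on this read-out lower numbers stand for stronger inhibition and higher numbers for weaker inhibition. Compound 1 `COc1ccc(-c2nn3cc(-c4cccc(N)c4)nc3s2)cc1OC` gives 16000 nM, and compound 3 `COc1ccc(-c2csc3nc(-c4cccc(N)c4)cn23)cc1` gives 19000 nM. Compound 2 `C=C(Br)C(=O)Nc1cccc(-c2cn3nc(-c4ccc(OCC)cc4)sc3n2)c1` gives 790 nM, the lowest of the three, with compound 1 and compound 3 both beyond the scatter above it. Compound 4 `C=C(Br)C(=O)Nc1cccc(-c2cn3nc(-c4ccc(F)cc4)sc3n2)c1` is not yet measured. It differs from compound 2 in one place: fluoro in place of ethoxy on an aromatic carbon. Going by the values given here, no pair of measured compounds shows this same change, so its size is unknown from the series; a step towards a higher number, around the edge of the scatter, is expected in this assay, namely a 1.9-fold higher number from compound 2 to compound 4 (0.28 log units; within the scatter). For compound 4 the estimate is 1500 nM, with a range from 500 nM to 5000 nM.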

Compound 4, half-maximal inhibitory concentration: 250 nM
Estimate against measurement, compound 4: 6.0-fold (0.78 log units) above; measured number outside the range, below it.
By their numbers in this assay, from the lowest: compound 4; then compound 2; then compounds 1 and 3 (each within the scatter of the next).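

Going from 4-ethoxyphenyl to 4-fluorophenyl gives a 3.2-fold lower number from compound 2 to compound 4 (0.50 log units; beyond the scatter) in this assay and so gives the first reading of this position. Ethoxy is not required on this aromatic carbon, para to a large group, and the change to fluoro, with fewer heavy atoms, lowers the number beyond the scatter. Nothing available explains the drop.

Still open, going by these compounds, is whether the trend follows from the removal of ethoxy or is specific to fluoro, which a hydrogen, chloro or methoxy at this carbon would separate. An amine or a carboxylic acid here also remains untested in the compounds shown.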